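Aromatic nitrogen substituents: 4-cyanobutyl to cyclopentyl

The source may report more compounds than this note shows. Statements on the series, on what has been measured and on what is new or still open speak of the compounds shown alone.

Compound 1 `CN1C(=S)[C@@H](NC(=O)c2nc(Cc3ccccc3)n(C)n2)COc2ccccc21`: 2.5 nM
Compound 2 `CC(C)n1nc(C(=O)N[C@H]2COc3ccccc3N(C)C2=S)nc1Cc1ccccc1`: 360 nM
Compound 3 `CN1C(=S)[C@@H](NC(=O)c2nc(Cc3ccccc3)n(CCCCC#N)n2)COc2ccccc21`: 2680 nM
Compound 4 `CN1C(=S)[C@@H](NC(=O)c2nc(Cc3ccccc3)n(C3CCCC3)n2)COc2ccccc21`: not yet measured

In a functional assay on HT-29 cells (Homo sapiens) for inhibition, read by luminescence and CellTiter-Glo, with a stated time of 24 h (a higher number here means that more compound is needed for the effect, a lower number that less compound is needed), compound 3 has the highest number of the measured set, with a 7.4-fold higher number from compound 2 to compound 3 (0.87 log units; beyond the scatter) and a 1100-fold higher number from compound 1 to compound 3 (3.03 log units; beyond the scatter). The next change is cyclopentyl in place of 4-cyanobutyl on an aromatic nitrogen. Going by the values given here, no measured compound carries cyclopentyl. The nearest guide is the isopropyl of compound 2, while a 140-fold higher number from compound 1 to compound 2 (2.16 log units; beyond the scatter) is a large step that warns against expecting a return towards compound 1. Compound 4 is therefore expected to land near compound 2, a modest fall in the number. The expected step is a 3.4-fold lower number from compound 3 to compound 4 (0.53 log units; beyond the scatter). Compound 4 is estimated at 800 nM, with an expected range of 150 nM to 4000 nM.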

Compound 4, half-maximal effective concentration: 3530 nM
For compound 4 the middle estimate is 4.4-fold (0.64 log units) below the measured one, and the stated range covers the measured number.
By their numbers in this assay, from the lowest: compound 1; then compound 2; then compounds 3 and 4 (each within the scatter of the next).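

Cyclopentyl and 4-cyanobutyl on this aromatic nitrogen cannot be told apart in this assay (a 1.3-fold higher number from compound 3 to compound 4 (0.12 log units; within the scatter)), so a ring of carbon only and an open chain ending in a nitrile give the same reading here. Cyclopentyl also extends the rise seen with isopropyl (a 9.8-fold higher number from compound 2 to compound 4 (0.99 log units; beyond the scatter)) and lies far from methyl (a 1400-fold higher number from compound 1 to compound 4 (3.15 log units; beyond the scatter)), which makes methyl the only group shown with a low number. No measurement available explains these numbers. As far as these compounds go, whether ethyl, or a chain ending in an amine or a carboxylic acid, would return towards compound 1 remains open.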